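The compounds below may be only part of what the source reports. "The series", "measured", "known", "first", "only" and "open" are said of these compounds alone.

Measured so far:
Compound 1, `CCc1cccc(NC(=O)c2cccc(/C=C3\CC(=O)N(Cc4ccccc4)C3=O)c2)c1`, gives 91500 nM in an ADME assay on SW480 cells (Homo sapiens) for cytotoxicity, read by MTT assay, with a stated time of 72 h; a higher number here means a weaker inhibitor, a lower number a stronger inhibitor.
Compound 2, `CCc1cccc(NC(=O)c2cccc(/C=C3\CC(=O)N(c4ccccc4)C3=O)c2)c1`, gives 88600 nM in this assay.
Compound 3, `CCc1cccc(NC(=O)c2cccc(/C=C3\CC(=O)N(c4ccc(C)cc4)C3=O)c2)c1`, gives 65300 nM in this assay.

Among these three numbers compound 2 stands second highest. Its nearest neighbour is compound 1: a 1.0-fold lower number from compound 1 to compound 2 (0.01 log units; within the scatter). Its furthest is compound 3: a 1.4-fold lower number from compound 2 to compound 3 (0.13 log units; within the scatter). The remaining pair behaves the same way: a 1.4-fold lower number from compound 1 to compound 3 (0.15 log units; within the scatter). All three compounds therefore sit within the scatter of one another, and none can be called stronger or weaker than the rest.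

Compound 4, `O=C(Nc1cccc(F)c1)c1cccc(/C=C2\CC(=O)N(c3ccccc3)C2=O)c1`, is not yet measured. It differs from compound 2 in one place: fluoro in place of ethyl on an aromatic carbon. Among the compounds with values here, every measured step so far alters the group on the amide-type nitrogen in the ring, and none touches the six-membered aromatic ring of carbon only where this change sits. Within the data shown here, no measured step therefore bears directly on it. What the data do show is a series that has stayed flat within the scatter across three changes, which gives no reason to expect a large move here.

For compound 4 the expected step is a 1.0-fold lower number from compound 2 to compound 4 (0.02 log units; within the scatter), with no direction beyond the scatter. The estimate for compound 4 in this assay is 85000 nM, with a likely range from 35000 nM to 220000 nM.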

Compound 4, half-maximal inhibitory concentration: > 100000 nM
Compound 4: no number, only a limit (the forecaster's own chance of this, stated with the estimate: 15%); middle value at least 1.1-fold (0.07 log units) away from the limit.
By their numbers in this assay, from the lowest: compounds 3, 2 and 1 (each within the scatter of the next). At a limit, above all of these: compound 4.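

Within the data shown here, compound 4 gives the first reading from the six-membered aromatic ring of carbon only that carries the ethyl group, since every earlier step changed the group on the amide-type nitrogen in the ring. In this assay, compound 4 has no number, only a limit: the limit of > 100000 nM in this assay, at which 1 of the 4 values shown sits. Putting fluoro in place of ethyl on this aromatic carbon gives an at least 1.1-fold higher number from compound 2 to compound 4 (0.05 log units; that floor lies within the scatter), so the true gap has a floor but no known ceiling, and that floor alone does not separate the two compounds; what can be said is that this change gives no sign of a stronger inhibitor.

The compounds shown leave open how much the group at this place matters, as a single change ending at a limit cannot say whether compound 4 truly lies far from compound 2 or close to it. An amine, a carboxylic acid or a longer chain such as propyl on the same aromatic carbon would show whether any group here can move the number beyond the scatter.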